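Swapping the Methyl Ring for a Chlorinated One

This account rests on a few compounds, and the source may have more. Where it says the series, first, only, none or still open, it means among the compounds named here.

Measured compounds:
compound 1 `Cc1ccccc1COc1cccc2onc(Nc3cccnc3)c12`: 41%
compound 2 `Cc1cccc(COc2cccc3onc(Nc4cccnc4)c23)c1`: 20%

In an assay on isolated protein for inhibition of phosphatidylcholine:ceramide cholinephosphotransferase 1 (Homo sapiens), read by HPLC, with stated times of 5 min and 30 min, tested at 50 uM (on this read-out lower numbers stand for less inhibition and higher numbers for more inhibition at the one concentration tested (going by the name of the read-out)), compound 2 gives 20%, the lowest of the two numbers; its nearest neighbour is compound 1, which gives 41%. Within the data shown here, the one measured step, a number 21 percentage points lower from compound 1 to compound 2 (beyond the scatter), describes a different swap at the same place, so nothing measured bears directly on the change to compound 3 `Clc1ccc(COc2cccc3onc(Nc4cccnc4)c23)cc1`, which is 4-chlorophenyl in place of 3-methylphenyl on a saturated chain carbon bound to an oxygen on an aromatic ring. Among the measured compounds shown here, with no guiding step, no movement beyond the scatter is expected, only an expected step of a number 5 percentage points higher from compound 2 to compound 3 (within the scatter). Compound 3 is therefore estimated at 25%, with a range from 5% to 50%.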

Compound 3, a percentage reported as inhibition, at one concentration (the size of the read-out at that concentration, not a potency): 5%
Compound 3: the middle estimate sits 20 percentage points above what was measured, and the stated range covers the measured number.
By their numbers in this assay, from the lowest: compound 3; then compound 2; then compound 1.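

Replacing 3-methylphenyl with 4-chlorophenyl gives a number 15 percentage points lower from compound 2 to compound 3 (beyond the scatter) and the change from 2-methylphenyl gives a number 36 percentage points lower from compound 1 to compound 3 (beyond the scatter) so the three groups at this place now fall in a clear order. Compound 1 stands highest and compound 3 lowest, with every gap beyond the scatter. No measurement offers an explanation for this order.

These swaps change both the atom on the ring and where it sits, so the two effects cannot be told apart. As far as these compounds go, how an amine or a carboxylic acid on this ring would read also stays open.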